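Adding a Second Fluorine to the Phenoxy Ring

The source may report more compounds than this note shows. Statements on the series, on what has been measured and on what is new or still open speak of the compounds shown alone.

Three compounds share one core and differ only in the fluorophenyl attached through oxygen on a saturated carbon. In a functional assay on HEK293 cells for positive allosteric modulation of metabotropic glutamate receptor 5 (Homo sapiens), read by calcium flux (on this read-out lower numbers stand for smaller maximal responses and higher numbers for larger maximal responses), compound 1 `O=C(c1ccc(F)cc1)N1CCc2nc(COc3ccccc3F)oc2C1` gives 78%, compound 2 `O=C(c1ccc(F)cc1)N1CCc2nc(COc3cccc(F)c3)oc2C1` gives 78%, and compound 3 `O=C(c1ccc(F)cc1)N1CCc2nc(COc3ccc(F)cc3)oc2C1` gives 73%. Compound 3 stands apart from the other two only by amounts inside the usual scatter: a number 5 percentage points lower from compound 1 to compound 3 (within the scatter) and a number 5 percentage points lower from compound 2 to compound 3 (within the scatter), while no change at the digits printed from compound 1 to compound 2 (within the scatter). Compound 4 `O=C(c1ccc(F)cc1)N1CCc2nc(COc3ccc(F)c(F)c3)oc2C1` differs from compound 3 in one place: fluoro in place of hydrogen on an aromatic carbon. For the measured compounds named here, the steps that bear on this change are the exchanges of one fluorophenyl for another, and none of them left the scatter. A fourth arrangement of fluorine on the same ring is therefore expected to produce no step beyond the scatter in this assay, in either direction. Compound 4 is estimated at 74%, with a range from 62% to 86%. The expected step is a number 1 percentage points higher from compound 3 to compound 4 (within the scatter).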

Compound 4, largest response reached (reported as percent of maximum), in percent of the reference or control that the assay uses: 40%
Beside the measured number, compound 4's estimate is 34 percentage points above it; the measured number lies below the stated range.
By their numbers in this assay, from the lowest: compound 4; then compounds 3, 1 and 2 (each within the scatter of the next).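

In this assay, the 3-fluorophenyl of compound 2 and the 4-fluorophenyl of compound 3 sit within the scatter of each other, yet the 3,4-difluorophenyl group that unites both fluorines brings a large fall: a number 33 percentage points lower from compound 3 to compound 4 (beyond the scatter) and a number 38 percentage points lower from compound 2 to compound 4 (beyond the scatter). Each single fluorine is thus tolerated while the pair is not, so this position on the ring, ortho to a fluoro group, responds in a way that moving one fluorine never revealed, and the fall also holds against the 2-fluorophenyl, with a number 38 percentage points lower from compound 1 to compound 4 (beyond the scatter). Nothing available explains this fall.

From the compounds shown here alone, whether it is specific to a second fluoro remains open, since a chloro, methyl or methoxy group at the same place could behave differently. The 2,4-difluorophenyl and 3,5-difluorophenyl patterns would show whether any second fluorine lowers the response or only this arrangement does.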